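The compounds below may be only part of what the source reports. "The series", "measured", "known", "first", "only" and "open" are said of these compounds alone.

Working notes on the series. Compound 1 `O=C(/C=C/c1ccc(OCc2cn(Cc3ccccc3)nn2)cc1)c1ccc(Br)cc1` is the reference point; in a functional assay on MIA PaCa-2 cells (Homo sapiens) for inhibition, read by MTT assay, with a stated time of 48 h, tested at 10 uM (a lower number here means less inhibition of growth, a higher number more inhibition of growth at the concentration tested), compound 1 gives 44%, the highest of the three numbers in hand. Compound 2 `O=C(/C=C/c1ccc(OCc2cn(Cc3cccc(Br)c3)nn2)cc1)c1ccc(Br)cc1` carries a bromo in place of hydrogen on the benzyl ring of the triazole; compound 2 gives 43%, and the step of a number 1 percentage points lower from compound 1 to compound 2 (within the scatter) falls within the scatter. Compound 3 `O=C(/C=C/c1ccc(OCc2cn(Cc3ccccc3F)nn2)cc1)c1ccc(Br)cc1` carries a fluoro on that same ring; compound 3 gives 28%, so the step of a number 16 percentage points lower from compound 1 to compound 3 (beyond the scatter) is modest but beyond the scatter, as is the step of a number 15 percentage points lower from compound 2 to compound 3 (beyond the scatter).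

Compound 4 `O=C(/C=C/c1ccc(OCc2cn(Cc3ccccc3)nn2)cc1)c1ccc([N+](=O)[O-])cc1` is the next member: nitro in place of bromo on an aromatic carbon. Among the measured compounds shown here, none of the measured steps touches this part of the molecule; all three changes so far sit on the benzyl ring at the triazole, and none of them moved this assay by more than a modest amount. For the measured compounds named here, there is therefore no direct precedent for a change on the carbonyl side, and nothing suggests a large move either way. The expected step of a number 2 percentage points lower from compound 1 to compound 4 (within the scatter) is accordingly none beyond the scatter. For compound 4 the estimate in this assay is 42%, with a range from 25% to 58%.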

Compound 4, percent growth inhibition at one concentration: "not active" (no number reported)
No number was reported for compound 4; there is nothing to compare the estimate with.
By their numbers in this assay, from the lowest: compound 3; then compounds 2 and 1 (each within the scatter of the next).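

In this assay, among the compounds shown here, compound 4 is reported only as "not active", without a number, so no step from compound 1 or any other compound to compound 4 can be read. No supporting data bear on the reason for this result. The compounds shown leave open how far 4-nitrophenyl in place of 4-bromophenyl shifts growth inhibition, and how other changes on that ring would read.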